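Propyl added to the benzamide ring of compound 2

The source may hold more compounds than are shown below. What is called first, only, known or untested is meant among the compounds shown, and "the series" means these compounds.

Measured so far:
compound 2 `O=C(COc1ccc2c(=O)ccoc2c1)Nc1cccc(NC(=O)c2ccccc2)c1`: 16 nM
compound 1 `COc1cccc(OCC(=O)Nc2cccc(NC(=O)c3ccc(N(C)C)cc3)c2)c1`: 5740 nM

In an assay on isolated protein for inhibition of Rho-associated protein kinase 2 (Homo sapiens), read by scintillation counting, radiometric assay and 33P incorporation, with a stated time of 40 min, in the presence of a further agent that is not named here (a higher number here means a weaker inhibitor, a lower number a stronger inhibitor), compound 2 gives 16 nM, the lowest of the two numbers. Compound 1 gives 5740 nM, a gap beyond the scatter, but compound 1 differs from compound 2 in more than one place, so no single step can be read from that pair.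

Compound 3 `CCCc1ccc(C(=O)Nc2cccc(NC(=O)COc3ccc4c(=O)ccoc4c3)c2)cc1` differs from compound 2 by propyl in place of hydrogen on an aromatic carbon. Going by the values given here, no measured pair shows this change, so the step is uncertain; a small shift, possibly a modest loss, is expected: a 1.9-fold higher number from compound 2 to compound 3 (0.27 log units; within the scatter). Compound 3 is expected to give 30 nM, with a range of 8 nM to 150 nM.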

Compound 3, half-maximal inhibitory concentration: 14 nM
For compound 3 the middle estimate is 2.1-fold (0.33 log units) above the measured one, and the stated range covers the measured number.
By their numbers in this assay, from the lowest: compounds 3 and 2 (each within the scatter of the next); then compound 1.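

A propyl group on the aromatic carbon para to a large group on the benzamide ring is tolerated: in this assay the step is a 1.1-fold lower number from compound 2 to compound 3 (0.06 log units; within the scatter). The earlier compounds shown here could not show this, as compound 1 differs from compound 2 in more than one place. No measurement here speaks to the reason for this tolerance.

Still open, as far as these compounds go, is whether a longer chain, an amine or a carboxylic acid at this position would stay within the scatter of compound 2. Whether propyl is also tolerated on the core of compound 1 is open too.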